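The compounds below may be only part of what the source reports. "The series", "measured", "known", "first", "only" and "open" are said of these compounds alone.

Measured so far:
compound 1, `Cc1ccccc1Nc1nc(Nc2ccccn2)ncc1Cl`, with 20100 nM
compound 2, `Cc1ccc(CNc2nc(Nc3ccc(N4CCN(C)CC4)cn3)ncc2Cl)cc1`, with 12700 nM

Of the compounds shown here, two have been measured in a functional assay on Jurkat cells (Homo sapiens) for inhibition, read by CCK-8 assay, with a stated time of 48 h; on this read-out lower numbers stand for stronger inhibition of growth and higher numbers for weaker inhibition of growth. Compound 1, `Cc1ccccc1Nc1nc(Nc2ccccn2)ncc1Cl`, gives 20100 nM. Compound 2, `Cc1ccc(CNc2nc(Nc3ccc(N4CCN(C)CC4)cn3)ncc2Cl)cc1`, gives 12700 nM, the lower of the two numbers, although the gap to compound 1 is within the scatter of repeated measurements, so no order between them can be claimed. No pair of these compounds differs in one place, so no single step has been measured.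

Compound 3, `COc1ccc(Nc2nc(Nc3ccc(N4CCN(C)CC4)cn3)ncc2Cl)cc1`, has not yet been measured. It differs from compound 2 in one place: 4-methoxyphenyl in place of 4-methylbenzyl on a nitrogen on an aromatic ring. For the measured compounds named here, with no measured step to lean on, the change is expected to give at most a modest step in this assay, most likely toward a lower number, with a 1.6-fold lower number from compound 2 to compound 3 (0.20 log units; within the scatter) as the estimated step from compound 2 to compound 3. Compound 3 is therefore expected to give about 8000 nM, within a range from 2500 nM to 25000 nM.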

Compound 3, concentration for 50% growth inhibition: 11200 nM
For compound 3 the middle estimate is 1.4-fold (0.15 log units) below the measured one, within the range that was stated.
By their numbers in this assay, from the lowest: compounds 3, 2 and 1 (each within the scatter of the next).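

In this assay, putting 4-methoxyphenyl in place of 4-methylbenzyl on a nitrogen on an aromatic ring gives a 1.1-fold lower number from compound 2 to compound 3 (0.05 log units; within the scatter), so the two compounds cannot be told apart. For the compounds shown here, this is the first single step available, and it shows that this place tolerates the exchange of one group for the other, even though the entering group brings a hydrogen-bond acceptor and the leaving group brings none. Nothing measured here offers an explanation for this result.

On these data alone, it remains open whether a group of another kind at this nitrogen, such as a simple alkyl amine, a carboxylic acid or a longer chain, would move the number beyond the scatter. Going by these compounds alone, compound 1 differs from compound 2 and compound 3 in more than one place, so it gives no single step to set beside this one.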